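Replacing pyrrolidin-2-yl with a hexenyl chain at the sulfonyl

The compounds below may be only part of what the source reports. "The series", "measured", "known", "first", "only" and "open" are said of these compounds alone.

Of the compounds shown here, three sharing one core have been measured in a functional assay, read by fluorescence and spectrophotometry, with a stated time of 1 h; a higher number here means that more compound is needed for the effect, a lower number that less compound is needed. Compound 1 `CCCCCCCCCCS(=O)(=O)/C=C/c1ccc(O)c(O)c1` gives 6800 nM and compound 2 `CCCCCCCS(=O)(=O)/C=C/c1ccc(O)c(O)c1` gives 7100 nM, a step of a 1.0-fold higher number from compound 1 to compound 2 (0.02 log units; within the scatter). Compound 3 `O=S(=O)(/C=C/c1ccc(O)c(O)c1)CC1CCCN1` gives 13800 nM, the highest of the three numbers; the step of a 1.9-fold higher number from compound 2 to compound 3 (0.29 log units; within the scatter) is its nearest gap, while its gap to compound 1 lies beyond the scatter. Compound 4 `C=CCCCCCS(=O)(=O)/C=C/c1ccc(O)c(O)c1` differs from compound 3 by hex-5-en-1-yl in place of pyrrolidin-2-yl on a saturated chain carbon bound to a sulfonyl sulfur. The step that bears on this is the one from hexyl to pyrrolidin-2-yl, which compound 4 reverses in kind by restoring a chain. Because the step of a 1.9-fold higher number from compound 2 to compound 3 (0.29 log units; within the scatter) lay within the scatter, compound 4 is expected to show a step of a 2.0-fold lower number from compound 3 to compound 4 (0.29 log units; within the scatter) back toward the lower numbers. Compound 4 is estimated at 7000 nM, within 3500 nM to 14000 nM.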

Compound 4, half-maximal effective concentration: 7100 nM
The estimate for compound 4 lay 1.0-fold (0.01 log units) below the measured number; measured number inside the range.
By their numbers in this assay, from the lowest: compounds 1, 2, 4 and 3 (each within the scatter of the next, the first and the last beyond it).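

In this assay the exchange of pyrrolidin-2-yl for hex-5-en-1-yl gives a 1.9-fold lower number from compound 3 to compound 4 (0.29 log units; within the scatter) and so, like the earlier step from the hexyl chain, shows no clear effect of this change at this position. A double bond in the chain adds nothing readable: vinyl in place of ethyl gives no change at the digits printed from compound 2 to compound 4 (within the scatter) and vinyl in place of pentyl gives a 1.0-fold higher number from compound 1 to compound 4 (0.02 log units; within the scatter) so the three chains cannot be told apart here. Nothing available explains these numbers. Going by these compounds, whether an open-chain amine, a carboxylic acid or a longer chain on this carbon would give a step beyond the scatter remains open.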